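Swapping a Benzyl for a Cyclohexyl in a Histamine Agonist

The source may hold more compounds than are shown below. What is called first, only, known or untested is meant among the compounds shown, and "the series" means these compounds.

Three compounds share a core built around an aminothiazole and a guanidine joined to an acyl group, and each has been tested in a functional assay on HEK293T cells for agonist activity at histamine H2 receptor (Homo sapiens), read by beta-arrestin recruitment; a lower number here means that less compound is needed, a higher number that more compound is needed for the effect. Compound 1, `Cc1nc(N)sc1CCCN/C(N)=N/C(=O)NC(C)c1cccc(F)c1`, gives 64.6 nM in this assay. Compound 3, `N/C(=N\C(=O)NCc1ccccc1)NC1CCc2nc(N)sc2C1`, gives 4370 nM. Compound 2, `Cc1nc(N)sc1CCCN/C(N)=N/C(=O)NCC(C)CCc1ccccc1`, gives 355 nM, which places it second highest of the three numbers: compound 1 gives a clearly lower number and compound 3 a clearly higher one, both gaps lying beyond the usual scatter of repeats.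

Compound 4, `Cc1nc(N)sc1CCCN/C(N)=N/C(=O)NCC(C)CC1CCCCC1`, has not yet been measured. It differs from compound 2 in one place: cyclohexyl in place of benzyl on a saturated chain carbon, three bonds along the chain from an amide-type nitrogen. The six-membered ring at the end of the chain stays the same size, but a ring of carbon only that is aromatic gives way to one that is non-aromatic, while donors, acceptors and charge stay unchanged.

For the measured compounds named here, no measured pair among the three compounds shows this kind of change, so there is no direct guide. A modest step, hardly beyond the scatter, is expected, with the number drifting slightly upward: a 1.4-fold higher number from compound 2 to compound 4 (0.15 log units; within the scatter). Compound 4 is therefore estimated at 500 nM in this assay, within a range from 180 nM to 1500 nM.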

Compound 4, half-maximal effective concentration: 302 nM
For compound 4 the middle estimate is 1.7-fold (0.22 log units) above the measured one; measured number inside the range.
By their numbers in this assay, from the lowest: compound 1; then compounds 4 and 2 (each within the scatter of the next); then compound 3.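

Reading this assay, the step is a 1.2-fold lower number from compound 2 to compound 4 (0.07 log units; within the scatter), so this one pair gives the first direct look at this change and the two numbers cannot be told apart. On this chain, then, a six-membered aromatic ring of carbon only can give way to a six-membered non-aromatic ring of carbon only with no change that repeat measurements could separate from scatter, which means that agonist activity in this compound pair does not depend on the ring being aromatic. No measurement shown here explains why the two rings give such similar numbers, so the result stands as an observation without a cause attached.

The compounds shown leave open whether other end groups in the same place, such as a cyclopentyl ring, a pyridine ring or a piperidine ring, would also keep the number within the scatter of compound 2. They also leave open whether the same exchange behaves alike on a longer chain or on a chain without its methyl branch, since this is a single pair on a single chain.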